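Sulfonyl aryl exchange at the piperidine sulfonamide

The source may hold more compounds than are shown below. What is called first, only, known or untested is meant among the compounds shown, and "the series" means these compounds.

Compound 1 `CCN(Cc1ccccc1)C(=O)C1CCN(S(=O)(=O)c2cccc3c2OCCO3)CC1` reaches 53% in a functional assay on CHO cells for positive allosteric modulation of muscarinic acetylcholine receptor M5 (Homo sapiens), read by calcium flux; on this read-out higher numbers stand for larger maximal responses and lower numbers for smaller maximal responses. Compound 2 `CCN(Cc1ccccc1)C(=O)C1CCN(S(=O)(=O)c2c[nH]cn2)CC1` carries a smaller aromatic group on the sulfonyl sulfur, and in this assay compound 2 stands at "not determined" (no result reported), so no number anchors it. Compound 3 `CCN(Cc1ccccc1)C(=O)C1CCN(S(=O)(=O)c2ccc3cccnc3c2)CC1` differs from compound 2 by quinolin-7-yl in place of 1H-imidazol-4-yl on a sulfonyl sulfur. Among the compounds with values here, no measured step covers this change, and with compound 2 unnumbered the size and direction of the move in this assay cannot be read from the series; no shift beyond the scatter is assumed. Compound 3 is expected near 55%, within 30% to 85%.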

Compound 3, largest response reached (reported as percent of maximum), in percent of the reference or control that the assay uses: 66%
Compound 3: middle estimate off by 11 percentage points, on the low side; the range from low to high includes it.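

Within the data shown here, on the sulfonyl sulfur, quinolin-7-yl in place of 2,3-dihydro-1,4-benzodioxin-5-yl gives in this assay a number 13 percentage points higher from compound 1 to compound 3 (beyond the scatter) as the first readable step at this position, showing that the maximal response moves with the aromatic group held there. The step from compound 2 to compound 3 cannot be read, so 1H-imidazol-4-yl remains unplaced against either group. No available evidence accounts for the gain.

Open, from the compounds shown here alone, is whether a plain phenyl or a methyl on the sulfonyl sulfur keeps the response. Also open, going by these compounds, is whether another quinoline attachment point matches quinolin-7-yl.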